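This account rests on a few compounds, and the source may have more. Where it says the series, first, only, none or still open, it means among the compounds named here.

Measured compounds in an assay on liver (Sus scrofa) for inhibition of glucose-6-phosphatase catalytic subunit 1 (Homo sapiens), using microsomes; on this read-out higher numbers stand for weaker inhibition and lower numbers for stronger inhibition:

- compound 1 `Clc1cc(Cl)cc(/C=N/N(Cc2ccccc2)Cc2ccccc2)c1`: > 100000 nM, a limit of this assay, not a number
- compound 2 `C(=N/N(Cc1ccccc1)Cc1ccccc1)\c1ccco1`: 1100 nM
- compound 3 `C(=N/N(Cc1ccccc1)Cc1ccccc1)\c1cccs1`: 1500 nM

Compound 3 holds the highest of the two numbers shown; its nearest neighbour is compound 2, with a 1.4-fold higher number from compound 2 to compound 3 (0.13 log units; within the scatter), so the two sit within the scatter of each other. Compound 1 sits at the limit of > 100000 nM in this assay, at which 1 of the 3 values shown sits.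

Compound 4 `O=[N+]([O-])c1ccc(/C=N/N(Cc2ccccc2)Cc2ccccc2)o1` is not yet measured. It differs from compound 3 by 5-nitrofuran-2-yl in place of thiophen-2-yl on a carbon with a double bond to nitrogen.

Among the compounds with values here, the only measured step that touches this change is the exchange of the five-membered ring, a 1.4-fold higher number from compound 2 to compound 3 (0.13 log units; within the scatter), which stayed within the scatter. Within the data shown here, the nitro group on the furan ring is new to the series; no measured step bears on it. The large steps of an at least 90-fold lower number from compound 1 to compound 2 (1.95 log units; beyond the scatter) and an at least 66-fold lower number from compound 1 to compound 3 (1.82 log units; beyond the scatter) concern the loss of the 3,5-dichlorophenyl ring and do not apply here.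

Expectation for compound 4 in this assay: no step beyond the scatter, a 1.4-fold lower number from compound 3 to compound 4 (0.13 log units; within the scatter), with the estimate resting on compound 2 at 1100 nM and compound 3 at 1500 nM. The estimated value for compound 4 is 1100 nM, expected between 300 nM and 4500 nM.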

Compound 4, half-maximal inhibitory concentration: > 100000 nM
Compound 4 ended at the assay's limit; the forecaster's own chance of this, stated with the estimate: 5%; middle value at least 90-fold (1.95 log units) away from the limit.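

In this assay, the five-membered ring on the carbon with a double bond to nitrogen proves sensitive to substitution, with nitro in place of hydrogen on an aromatic carbon giving an at least 90-fold higher number from compound 2 to compound 4 (1.95 log units; beyond the scatter). Measured against thiophen-2-yl, 5-nitrofuran-2-yl gives an at least 66-fold higher number from compound 3 to compound 4 (1.82 log units; beyond the scatter), so this position responds strongly to a group on the ring, whereas exchanging the unsubstituted rings stayed within the scatter. Compound 4 carries a limit, not a number, and the step between compound 1 and compound 4 cannot be read: the limit of > 100000 nM in this assay, at which 2 of the 4 values shown sit.

As far as these compounds go, it remains open whether this loss is specific to nitro or would follow any group on the furan ring, such as methyl, an amine or a carboxylic acid. Equally open, from the compounds shown here alone, is whether nitro on the thiophene ring would behave the same way.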